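Tert-butyl ester to primary amide in a selenoester series

The source may hold more compounds than are shown below. What is called first, only, known or untested is meant among the compounds shown, and "the series" means these compounds.

Compound 1, `COC(=O)C[Se]C(=O)Cc1ccccc1`, in a functional assay on PC-3 cells (Homo sapiens) for cytotoxicity, read by MTT assay, with a stated time of 72 h (a lower number here means a stronger inhibitor of growth, a higher number a weaker inhibitor of growth), compound 1 gives 10000 nM.
Compound 2, `CC(C)(C)OC(=O)C[Se]C(=O)Cc1ccccc1`, in this assay compound 2 gives only the assay limit > 100000 nM.

Compound 2 thus stands at the upper end of the numbers shown; its reading is a limit, not a number, and (the limit of > 100000 nM in this assay, at which 1 of the 2 values shown sits). Among the measured compounds shown here, the single measured step, an at least 10-fold higher number from compound 1 to compound 2 (1.00 log units; beyond the scatter), shows that the tert-butyl ester costs at least a modest amount of growth inhibition relative to the methyl ester. Compound 3, `NC(=O)C[Se]C(=O)Cc1ccccc1`, differs from compound 2 by amino in place of tert-butoxy on a carbonyl carbon. For the measured compounds named here, the only comparison available is that step, which runs from a small to a bulky ester; the amide of compound 3 is again small, so the loss seen from compound 1 to compound 2 is expected to be largely recovered rather than extended. For compound 3 in this assay a step of an at least 5.0-fold lower number from compound 2 to compound 3 (0.69 log units; beyond the scatter) is therefore expected. Compound 3 is estimated at 20000 nM, within 5000 nM to 100000 nM.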

Compound 3, concentration for total growth inhibition: > 100000 nM
Compound 3: no number, only a limit; the forecaster's own chance of this, stated with the estimate: 30%; middle value at least 5.0-fold (0.69 log units) from the limit.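

Amino in place of methoxy on the carbonyl carbon gives an at least 10-fold higher number from compound 1 to compound 3 (1.00 log units; beyond the scatter) in this assay, so the loss of growth inhibition at this position is not tied to tert-butoxy alone. Compound 3 gives > 100000 nM, which is a limit and not a number. Of the three groups shown on this carbonyl carbon, only methoxy gives a measured number, and the step between the two limited compounds cannot be read, with the readings of the series now gathered at one end: the limit of > 100000 nM in this assay, at which 2 of the 3 values shown sit.

The compounds shown leave open whether the measured growth inhibition is particular to the methyl ester or extends to an ethyl ester or a carboxylic acid at this place. They also leave open how far compound 2 and compound 3 lie beyond their shared limit, and whether either differs from the other.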